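Trifluoromethoxy for Methyl at the Cytotoxicity Limit

The source may report more compounds than this note shows. Statements on the series, on what has been measured and on what is new or still open speak of the compounds shown alone.

Compound 3 `Cc1ccc(C(=O)Nc2cc3nc(C4CCCCC4)[nH]c3cc2N(C)C)cc1` stands at the ceiling of an ADME assay on Vero cells (Chlorocebus sabaeus) for cytotoxicity, read by resazurin assay, with a stated time of 3 days; a lower number here means a stronger inhibitor, a higher number a weaker inhibitor. In this assay compound 3 gives > 100 ug/mL, which is a limit of the assay and not a number. Its two close relatives share the same reading. Compound 1 `CN(C)c1cc2[nH]c(C3CCCCC3)nc2cc1NC(=O)c1ccc(Br)cc1` gives > 100 ug/mL in this assay, again a limit. Compound 2 `CCc1ccc(C(=O)Nc2cc3nc(C4CCCCC4)[nH]c3cc2N(C)C)cc1` gives > 100 ug/mL in this assay, also a limit. The steps among these three compounds are therefore unreadable: a step that the two limits leave unreadable from compound 1 to compound 3, a step that the two limits leave unreadable from compound 1 to compound 2 and a step that the two limits leave unreadable from compound 2 to compound 3. All three readings sit at the limit of > 100 ug/mL in this assay, at which 3 of the 3 values shown sit.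

Compound 4 `CN(C)c1cc2[nH]c(C3CCCCC3)nc2cc1NC(=O)c1ccc(OC(F)(F)F)cc1` differs from compound 3 by trifluoromethoxy in place of methyl on an aromatic carbon. Among the compounds with values here, none of the measured steps gives a readable size for a change of this kind, and each of them, whatever its direction, left both compounds at the limit. Compound 4 is therefore expected to stay at the limit as well, with a step that the limit leaves unreadable from compound 3 to compound 4 expected to be no larger than the scatter. The estimate for compound 4 in this assay is 120 ug/mL, within a range from 50 ug/mL to 300 ug/mL.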

Compound 4, half-maximal inhibitory concentration: > 100 ug/mL
Compound 4: only a limit was reported (the forecaster's own chance of this, stated with the estimate: 80%); the middle value does not contradict the limit.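

In this assay, within the data shown here, compound 4 gives > 100 ug/mL, again a limit of the assay and not a number, so no step to compound 4 from compound 1, compound 2 or compound 3 can be read. The compounds shown leave open what actual value any of the four has in this assay.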